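Ethyl added to the core of compound 3

This account rests on a few compounds, and the source may have more. Where it says the series, first, only, none or still open, it means among the compounds named here.

Three compounds have entries in a functional assay on 1A9 cells (Homo sapiens) for cytotoxicity; on this read-out lower numbers stand for an effect already at smaller amounts and higher numbers for an effect only at larger amounts of compound. For compound 1 `COC1=C(C)C(=O)/C(=C(O)/C=C/c2ccccc2C)C(=O)C1(C)C` the entry reads "not determined" (no result reported). For compound 2 `COC1=C(C)C(=O)/C(=C(O)/C=C/c2cccc3ccccc23)C(=O)C1(C)C` the entry also reads "not determined" (no result reported). For the measured compounds named here, compound 3 `COC1=CC(O)=C(C(=O)/C=C/c2ccccc2)C(=O)C1(C)C` gives 3.6 ug/mL, the only number, so it cannot yet be ranked against anything.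

Compound 4 `CCC1=C(OC)C(C)(C)C(=O)C(C(=O)/C=C/c2ccccc2)=C1O` is still to be measured and departs from compound 3 by a single change: ethyl in place of hydrogen on a double-bonded ring carbon.

Going by the values given here, no measured pair shows what such a change does, and compound 1 and compound 2 offer no number to compare. Going by these compounds, the direction of any shift therefore stays open, and no step beyond the scatter is expected in this assay. The expected size of the step of a 1.0-fold lower number from compound 3 to compound 4 (0.01 log units; within the scatter) is estimated to stay within the usual scatter. This expectation rests solely on compound 3 at 3.6 ug/mL, so the range is kept wide. For compound 4 the estimated value is 3.5 ug/mL, with an expected range from 1.5 ug/mL to 8 ug/mL.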

Compound 4, concentration for half-maximal effect: 3.8 ug/mL
Compound 4: the middle estimate sits 1.1-fold (0.04 log units) below what was measured; the range from low to high includes it.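

In this assay, for the compounds shown here, ethyl in place of hydrogen on a double-bonded ring carbon gives a 1.1-fold higher number from compound 3 to compound 4 (0.02 log units; within the scatter) and this pair is the first with a number on both sides. The position, on the six-membered ring next to the ring atoms that bear the hydroxy and methoxy groups, therefore takes ethyl with no step beyond the scatter in this read-out. No data at hand offer an explanation for this result.

Going by these compounds, one change at one position sets no trend, so whether a longer chain such as butyl, an amine or a carboxylic acid on this ring carbon would also stay within the scatter remains open. Also open, on these data alone, is how ethyl at this position would read on the core of compound 1 or compound 2, whose entries carry no number, and whether the result holds outside these cells.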